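Dropping One Fluorine from a Pendant Phenyl Ring

The source may hold more compounds than are shown below. What is called first, only, known or untested is meant among the compounds shown, and "the series" means these compounds.

Three compounds share one core and differ only in the aromatic ring hanging off it. Compound 1 `COc1ccc(-n2nc(C(=O)Nc3ccc(Oc4ccncc4-c4cccnc4)c(F)c3)c3ccccc3c2=O)cc1` carries a 4-methoxyphenyl there, but in a functional assay on HT-29 cells (Homo sapiens) for cytotoxicity, read by MTT assay, with a stated time of 72 h (a lower number here means a stronger inhibitor, a higher number a weaker inhibitor), compound 1 shows "not determined" (no result reported), so no result was reported for it. Going by the values given here, compound 2 `O=C(Nc1ccc(Oc2ccncc2-c2cccnc2)c(F)c1)c1nn(-c2cccc(F)c2)c(=O)c2ccccc12` carries a 3-fluorophenyl, and in this assay compound 2 gives 410 nM, the only number in this set; it stands alone, with nothing measured to compare it against. Compound 3 `O=C(Nc1ccc(Oc2ccncc2-c2cccnc2)c(F)c1)c1nn(-c2ccccc2)c(=O)c2ccccc12` is the next step: hydrogen in place of fluoro on an aromatic carbon. Cut one bond further out, the 3-fluorophenyl becomes a plain phenyl and nothing else moves.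

Among the compounds with values here, no step between two measured compounds exists here, so there is no measured example of how this change behaves. Because compound 2 gives 410 nM and nothing but a single fluorine leaves with no donor or acceptor gained or lost, the expected step is estimated as a 1.2-fold higher number from compound 2 to compound 3 (0.09 log units; within the scatter), which lies within the scatter of repeated measurements. Compound 3 is accordingly estimated at 500 nM in this assay, with a likely range from 200 nM to 1500 nM.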

Compound 3, half-maximal inhibitory concentration: 1240 nM
Compound 3: middle estimate off by 2.5-fold (0.39 log units), on the low side; measured number inside the range.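

In this assay, a single atom on the pendant ring proves able to shift the result: a 3.0-fold higher number from compound 2 to compound 3 (0.48 log units; beyond the scatter) is a step beyond the usual scatter, with the 3-fluorophenyl of compound 2 the stronger inhibitor and the plain phenyl of compound 3 the weaker. Before this pair, the series offered only one number, so nothing showed whether this ring responded to any change at all; now there is one measured case, in which only a fluorine on an aromatic carbon, meta to a large group, gives way to a hydrogen. No measurement available here gives a reason for this difference.

Steps involving compound 1 and its 4-methoxyphenyl cannot be read, so the pair of compound 2 and compound 3 remains the only comparison at this position. Also open, as far as these compounds go, is how other groups would behave on the same carbon, such as a chlorine atom, a methyl, a nitrile or an amine, and whether any of them would match or exceed the fluorine.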